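Stripping the Carbamoyl Group: What to Expect for Compound 4

The compounds below may be only part of what the source reports. "The series", "measured", "known", "first", "only" and "open" are said of these compounds alone.

compound 1 `O=C1NCCN1C(c1ccccc1)(c1ccccc1)c1ccccc1`: 27000 nM
compound 2 `COc1cc(NC(C)CCCNC(=O)NNC(=O)N(CCO)CCO)c2ncccc2c1`: a limit, > 250000 nM
compound 3 `COc1cc(NC(C)CCCNC(=O)NNC(=O)Nc2ccc(Cl)c(C(F)(F)F)c2)c2ncccc2c1`: 14000 nM

In a functional assay on CCRF-CEM cells (Homo sapiens) for inhibition, read by MTT assay, with a stated time of 4 days (on this read-out lower numbers stand for stronger inhibition and higher numbers for weaker inhibition), compound 1 gives 27000 nM and compound 3 gives 14000 nM. From the compounds shown here alone, for compound 2 the assay reports only a limit, > 250000 nM, so its true number is unknown. Compound 4 `COc1cc(NC(C)CCCNC(=O)NN)c2ncccc2c1` is compound 2 with hydrogen in place of bis(2-hydroxyethyl)carbamoyl on an amine nitrogen. Among the compounds with values here, the only measured step, an at least 17-fold lower number from compound 2 to compound 3 (1.25 log units; beyond the scatter), starts from that same limit and replaces the bis(2-hydroxyethyl)amino part with (4-chloro-3-(trifluoromethyl)phenyl)amino on a carbonyl carbon; here the whole bis(2-hydroxyethyl)carbamoyl group is removed instead, leaving a much smaller molecule. Because compound 2 sits at the limit of > 250000 nM in this assay, at which 1 of the 3 values shown sits, no step size can be read off directly. Compound 4 is expected at about 200000 nM, between 40000 nM and 1000000 nM. The expected step of an at least 1.2-fold lower number from compound 2 to compound 4 (0.09 log units; that floor lies within the scatter) is small, with a fair chance of another limit.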

Compound 4, half-maximal inhibitory concentration: > 250000 nM
Compound 4 ended at the assay's limit; the forecaster's own chance of this, stated with the estimate: 60%; middle value at least 1.2-fold (0.09 log units) from the limit.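

Compound 2 and compound 4 both stop at a limit, not a number, so no step between them can be read: the limit of > 250000 nM in this assay, at which 2 of the 4 values shown sit.

The compounds shown leave open whether hydrogen in place of bis(2-hydroxyethyl)carbamoyl changes inhibition at all.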